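Butyl for Isopropyl: Expected Cytotoxicity of Compound 4

The source may hold more compounds than are shown below. What is called first, only, known or untested is meant among the compounds shown, and "the series" means these compounds.

Measured so far:
Compound 1 `COCCOc1nc(N)nc2c1ncn2/C=C1/CC1(CO)CO` gives > 20000 nM in an ADME assay on BCBL1 cells (Homo sapiens) for cytotoxicity, with a stated time of 7 days (on this read-out higher numbers stand for lower toxicity in this test and lower numbers for higher toxicity in this test), which is a limit of the assay.
Compound 2 `CC(C)Nc1nc(N)nc2c1ncn2/C=C1/CC1(CO)CO` gives > 20000 nM in this assay, again a limit.
Compound 3 `Nc1nc2c(ncn2/C=C2/CC2(CO)CO)c(=O)[nH]1` gives > 20000 nM in this assay, also a limit.

Compound 2 therefore stands at the assay limit, where every value here sits (the limit of > 20000 nM in this assay, at which 3 of the 3 values shown sit). Going by the values given here, the only single-point step, a step that the two limits leave unreadable from compound 1 to compound 2, starts and ends at that limit and so has no readable size. Compound 4 `CCCCNc1nc(N)nc2c1ncn2/C=C1/CC1(CO)CO` differs from compound 2 by butyl in place of isopropyl on a nitrogen on an aromatic ring. Among the compounds with values here, no measured step bears directly on this change; the shared behaviour of all three measured compounds is the only guide. Compound 4 is expected to show no step beyond the scatter, a step that the limit leaves unreadable from compound 2 to compound 4. The estimate for compound 4 is 40000 nM, ranging from 15000 nM to 150000 nM, most likely reported as a limit.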

Compound 4, half-maximal cytotoxic concentration: > 20000 nM
Compound 4 gave a limit, no number; the forecaster's own chance of this, stated with the estimate: 85%; the middle value is on the limit's open side.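

Compound 4 is again only a limit, so its steps from compound 1 and compound 2 cannot be read, because every value sits at the same limit: the limit of > 20000 nM in this assay, at which 4 of the 4 values shown sit.

The compounds shown leave open whether any of these changes shifts the read-out in this assay.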